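This account rests on a few compounds, and the source may have more. Where it says the series, first, only, none or still open, it means among the compounds named here.

Measured compounds:
Compound 1 `Cc1cnccc1-c1nccc2nc(N)nn12`: 2500 nM; 2500 nM (2 entries)
Compound 2 `Nc1nc2ccnc(-c3cccc(C=O)c3)n2n1`: 700 nM

Among the compounds with values here, in a functional assay (Homo sapiens) (on this read-out lower numbers stand for stronger inhibition and higher numbers for weaker inhibition), compound 2 gives 700 nM, and this is the one single number recorded for it, with a further entry that yields no single number. Compound 1 in this assay gives 2500 nM; 2500 nM (2 entries) on two entries, so of the two values shown, that of compound 2 is the lower. Within the data shown here, no step between these two compounds is computed, as they differ in more than one place.

Compound 3 `Nc1nc2ccnc(-c3cccc(Cl)c3)n2n1` has not yet been measured in this assay. It differs from compound 2 by chloro in place of formyl on an aromatic carbon. With no comparable change among the measured compounds, the size of the step is uncertain; a modest shift toward weaker inhibition, or none beyond the scatter, is expected as a 1.4-fold higher number from compound 2 to compound 3 (0.15 log units; within the scatter). Compound 3 is therefore expected to give about 1000 nM, within a range from 300 nM to 3500 nM.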

Compound 3, half-maximal inhibitory concentration: 4300 nM
The estimate for compound 3 lay 4.3-fold (0.63 log units) below the measured number; measured number above the stated range.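

In this assay, chloro in place of formyl on an aromatic carbon, meta to a large group, gives a 6.1-fold higher number from compound 2 to compound 3 (0.79 log units; beyond the scatter) and thus a change that exceeds the usual scatter. Within the data shown here, this is the first comparison of two compounds that differ in one place, and it shows that inhibition depends on the group at this carbon of the six-membered aromatic ring, with formyl giving the stronger inhibition of the pair. No supporting measurement is available to explain the difference.

The pair cannot show whether the hydrogen-bond acceptor counted for formyl, its double bond or something else accounts for the step. Nor does it show how a nitrile, an amine, a carboxylic acid or a hydroxymethyl group at this carbon would compare with formyl and chloro.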